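A few compounds are considered here, and "the series" means these few. Any claim that something is new, unique, unknown or untested is made for them only; others in the source may bear on it.

Working notes on the series. Going by the values given here, compound 2 `O=C1c2ccccc2S(=O)(=O)N1CCCCCN1CCN(c2cccc(Cl)c2Cl)CC1` gives 149 nM in an assay on HEK293 cells for displacement of a labelled ligand from 5-hydroxytryptamine receptor 7 (Homo sapiens) (on this read-out lower numbers stand for stronger inhibition and higher numbers for weaker inhibition), and holds the lowest of the two numbers measured so far; the nearest is compound 1 `O=C1c2ccccc2S(=O)(=O)N1CCCCCN1CCN(c2ncccn2)CC1`, which in this assay gives 2670 nM. Among the compounds with values here, the only measured step, an 18-fold lower number from compound 1 to compound 2 (1.25 log units; beyond the scatter), lies on the amine nitrogen in the ring and shows that this assay answers strongly to what is attached there.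

Compound 3 `COc1ccccc1N1CCN(CCCCCN2C(=O)c3ccccc3S2(=O)=O)CC1`, still to be measured in this assay, alters the same position: 2-methoxyphenyl in place of 2,3-dichlorophenyl on an amine nitrogen in a ring. Within the data shown here, no measured compound carries 2-methoxyphenyl, so the one step that bears on it, an 18-fold lower number from compound 1 to compound 2 (1.25 log units; beyond the scatter), is informative only in size: it marks the position as one where a change can move the number well beyond the scatter, but gives no direction for this particular group. With nothing pointing either way, the working assumption is a number near that of compound 2, with a wide margin in both directions. Compound 3 is therefore expected at about 120 nM, within 35 nM to 420 nM. This corresponds to an expected step of a 1.2-fold lower number from compound 2 to compound 3 (0.09 log units; within the scatter) in this assay, which is within the scatter.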

Compound 3, inhibition constant: 125 nM
Compound 3: middle estimate off by 1.0-fold (0.02 log units), on the low side; the range from low to high includes it.
By their numbers in this assay, from the lowest: compounds 3 and 2 (each within the scatter of the next); then compound 1.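

In this assay, the step of a 1.2-fold lower number from compound 2 to compound 3 (0.08 log units; within the scatter) shows that 2-methoxyphenyl and 2,3-dichlorophenyl cannot be told apart on the amine nitrogen in the ring, even though the exchange replaces chlorine with an oxygen-bearing group and adds a hydrogen-bond acceptor. The second step, a 21-fold lower number from compound 1 to compound 3 (1.33 log units; beyond the scatter), is also large, so the earlier gap is no longer tied to 2,3-dichlorophenyl alone: among these three compounds, both groups with a six-membered aromatic ring of carbon only stand well apart from pyrimidin-2-yl, and no compound shown goes against this. Nothing available explains why these two groups match or why pyrimidin-2-yl differs.

The compounds shown leave open whether either substituent matters at all, since plain phenyl would separate the contribution of the carbon ring from that of the methoxy and chlorine groups, while pyridin-2-yl would test the step from pyrimidin-2-yl at the same position. They also leave open whether this near-equality of the two groups would hold with a longer chain, since all three compounds share the same chain and core.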